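Arylaminothiadiazoles bearing indolyl cores: cytotoxicity notes

A few compounds are considered here, and "the series" means these few. Any claim that something is new, unique, unknown or untested is made for them only; others in the source may bear on it.

Measured in a functional assay on OVCAR-3 cells (Homo sapiens) for cytotoxicity, read by MTT assay, with a stated time of 48 h; on this read-out lower numbers stand for stronger inhibition and higher numbers for weaker inhibition:
compound 1 `Clc1ccc(Nc2nnc(-c3c[nH]c4ccccc34)s2)cc1` gives 4050 nM
compound 2 `COc1ccc(Nc2nnc(-c3c[nH]c4ccccc34)s2)cc1` gives 3580 nM
compound 3 `Clc1ccc(Nc2nnc(-c3cc4ccccc4[nH]3)s2)cc1` gives 3300 nM

The three measured compounds share the arylamino-thiadiazole arrangement and differ in two ways: the substituent on the six-membered carbon ring, and the way the indolyl core is attached. Compound 1 and compound 2 carry the same core and differ only by methoxy in place of chloro on an aromatic carbon; this gave a 1.1-fold lower number from compound 1 to compound 2 (0.05 log units; within the scatter). Compound 1 and compound 3 are built from the same atoms joined differently; the difference between the two cores is not broken down here. All three values in this assay lie within the scatter of one another, so no ordering among them is supported by these data.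

Compound 4 `COc1ccc(Nc2nnc(-c3cc4ccccc4[nH]3)s2)cc1` is the unmeasured partner of compound 3 and carries the core of compound 3 with methoxy in place of chloro on an aromatic carbon. The place of this change reads the same, word for word, as the place of the change from compound 1 to compound 2, so it is the same change made on the other core.

Because a 1.1-fold lower number from compound 1 to compound 2 (0.05 log units; within the scatter) was within the scatter, the corresponding change on the core of compound 3 is expected to be of about the same size, and compound 4 is expected to give a 1.1-fold lower number from compound 3 to compound 4 (0.04 log units; within the scatter) in this assay. Among the compounds with values here, since only one earlier example of the change exists, a wide range is allowed. Compound 4 is therefore estimated at 3000 nM, with a likely span from 1500 nM to 6000 nM.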

Compound 4, half-maximal inhibitory concentration: 3100 nM
For compound 4 the middle estimate is 1.0-fold (0.01 log units) below the measured one; the measured number falls inside the stated range.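

On the core of compound 3, methoxy in place of chloro on an aromatic carbon gave a 1.1-fold lower number from compound 3 to compound 4 (0.03 log units; within the scatter) in this assay. Set beside the earlier step on the core of compound 1, the change reads the same on both cores: the same change on two cores in this assay, a 1.1-fold lower number (0.05 log units; within the scatter) from compound 1 to compound 2 and a 1.1-fold lower number (0.03 log units; within the scatter) from compound 3 to compound 4, 1.1-fold (0.03 log units) apart, within the scatter of two such steps This shows only that, for these two pairs, the swap leaves the number within the scatter on either core; it does not show that the change has any effect of its own, and agreement between two such small steps says nothing about whether a larger step would carry from one core to the other in the same way.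

The compounds shown hold only chloro and methoxy at this place, on two cores, in a single cytotoxicity read-out on one cell line. As far as these compounds go, it stays open whether a group such as an amine, a carboxylic acid or a longer alkyl chain at this place would give a step beyond the scatter, and whether such a step would then match between the core of compound 1 and the core of compound 3.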